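The source may report more compounds than this note shows. Statements on the series, on what has been measured and on what is new or still open speak of the compounds shown alone.

Compound 1 `CC(Sc1nc2c(cnn2C)c(=O)n1-c1ccccc1)c1cccc(F)c1` is the reference point of this comparison. In an assay on isolated protein for inhibition of Retinaldehyde dehydrogenase 3 (Homo sapiens) (on this read-out lower numbers stand for stronger inhibition and higher numbers for weaker inhibition), compound 1 gives 128 nM, which is the second highest of the three numbers recorded so far. Its nearest neighbour is compound 3 `COc1ccccc1C(C)Sc1nc2c(cnn2C)c(=O)n1-c1ccccc1`, which in this assay gives 112 nM; the furthest is compound 2 `Cn1ncc2c(=O)n(-c3ccccc3)c(CNc3cccc(F)c3)nc21`, which in this assay gives 1050 nM.

Among the compounds with values here, the only measured step that alters the aryl group on the chain is a 1.1-fold lower number from compound 1 to compound 3 (0.06 log units; within the scatter), and it lies within the scatter. Compound 2 differs from compound 1 at the linker rather than at the aryl group, so its value does not directly inform the present change.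

Compound 4 `C[C@@H](Sc1nc2c(cnn2C)c(=O)n1-c1ccccc1)c1ccccc1` has not yet been measured in this assay. It differs from compound 1 as follows: 1-phenylethyl in place of 1-(3-fluorophenyl)ethyl on a sulfur. Within the data shown here, no measured step removes a fluorine from that ring, but the step from compound 1 to compound 3 suggests the aryl substituent on the chain moves the number little. A step within the scatter, or at most a slight rise, is expected, i.e. a 1.4-fold higher number from compound 1 to compound 4 (0.15 log units; within the scatter). For compound 4 in this assay the estimate is 180 nM, in the range 70 nM to 450 nM.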

Compound 4, half-maximal inhibitory concentration: 34 nM
Compound 4: the middle estimate sits 5.3-fold (0.72 log units) above what was measured; the whole stated range lies above it.
By their numbers in this assay, from the lowest: compound 4; then compounds 3 and 1 (each within the scatter of the next); then compound 2.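

In this assay, within the data shown here, the 1-phenylethyl group on the sulfur gives a 3.8-fold lower number from compound 1 to compound 4 (0.58 log units; beyond the scatter), whereas the only earlier change at this position gave a 1.1-fold lower number from compound 1 to compound 3 (0.06 log units; within the scatter). This position therefore responds measurably to change, and the fluorine of the 1-(3-fluorophenyl)ethyl group is not required for inhibition at this level. Nothing available accounts for the size of this step.

The step removes the fluorine and also enters a defined stereocentre. The data do not separate these two changes, and the mirror-image form of compound 4 is an open comparison. Also open, going by these compounds, is how this position responds to an amine or a carboxylic acid on the phenyl ring, or to a longer chain in place of the ethyl.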